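Fluorine Count on the Cinnamamide Ring and Cytotoxicity

The compounds below may be only part of what the source reports. "The series", "measured", "known", "first", "only" and "open" are said of these compounds alone.

Compound 1 `COc1ccc(/C=C/C(=O)Nc2cc(C(=O)c3cc(OC)c(OC)c(OC)c3)cc(OC)c2OC)cc1`: 3800 nM
Compound 2 `COc1cc(C(=O)c2cc(OC)c(OC)c(OC)c2)cc(NC(=O)/C=C/c2ccc(F)cc2)c1OC`: 1800 nM

The two measured compounds share one core and differ only in the group at the end of the double-bonded chain. In a functional assay on HT-29 cells (Homo sapiens) for cytotoxicity, read by MTT assay, with a stated time of 72 h (on this read-out higher numbers stand for weaker inhibition and lower numbers for stronger inhibition), compound 1 gives 3800 nM, and compound 2 gives 1800 nM, the lowest of the two numbers; the step of a 2.1-fold lower number from compound 1 to compound 2 (0.32 log units; beyond the scatter) carries a fluoro in place of a methoxy on that ring.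

Compound 3 `COc1cc(C(=O)c2cc(OC)c(OC)c(OC)c2)cc(NC(=O)/C=C/c2cc(F)c(F)c(F)c2)c1OC` has not yet been measured. It differs from compound 2 by 3,4,5-trifluorophenyl in place of 4-fluorophenyl on a double-bonded chain carbon bound to a double-bonded chain carbon. Among the compounds with values here, this is a different kind of change from the one measured step: fluorine already present stays, and two more fluorine atoms join it on the same ring. Within the data shown here, no measured pair shows what adding fluorine to an already fluorinated ring does here, so the single step from compound 1 to compound 2 bears on it only loosely, as a sign that small changes on this ring move this assay modestly.

Compound 3 is therefore expected to stay near compound 2, with a step of a 1.2-fold lower number from compound 2 to compound 3 (0.08 log units; within the scatter), and an estimated value of 1500 nM, ranging from 500 nM to 4500 nM.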

Compound 3, half-maximal inhibitory concentration: 3300 nM
Compound 3: middle estimate off by 2.2-fold (0.34 log units), on the low side, and the stated range covers the measured number.
By their numbers in this assay, from the lowest: compounds 2, 3 and 1 (each within the scatter of the next, the first and the last beyond it).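

In this assay, the step of a 1.8-fold higher number from compound 2 to compound 3 (0.26 log units; within the scatter) lies within the scatter, so replacing 4-fluorophenyl with 3,4,5-trifluorophenyl at this place on the chain gives no clear shift in either direction. The step of a 1.2-fold lower number from compound 1 to compound 3 (0.06 log units; within the scatter) also lies within the scatter, whereas the step of a 2.1-fold lower number from compound 1 to compound 2 (0.32 log units; beyond the scatter) lies beyond it, which means compound 3 cannot be told apart from either of the other two, even though those two can be told apart from each other; the idea that more fluorine on this ring simply gives a lower number therefore finds no support, and compound 3 is the compound that goes against it. No measurement is available here that would explain this result.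

The compounds shown leave open how a ring carrying two fluorine atoms would fall relative to the one-fluorine and three-fluorine rings, which would show whether the count of fluorine atoms has any steady relation to the number in this assay. They also leave open what a different group at this end of the chain, such as a chloro, a nitrile, an amine or a carboxylic acid on the ring, would do.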